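Mirror-image piperidine amide: expectation for compound 4

The source may report more compounds than this note shows. Statements on the series, on what has been measured and on what is new or still open speak of the compounds shown alone.

Compound 3 `COc1cc(C(=O)N2CC[C@@H](O)[C@H](C)C2)cc2nc(NCc3cccc(Cl)c3)oc12` gives the lowest number among the three measured compounds in an assay on isolated protein for inhibition of thyroid hormone receptor beta (Homo sapiens), read by fluorescence, with a stated time of 30 min (a lower number here means a stronger inhibitor, a higher number a weaker inhibitor), at 10 nM. Compound 1 `CCCN(CC1CCOC1)C(=O)c1cc(OC)c2oc(NCc3cccc(Cl)c3)nc2c1` gives 12 nM, a gap within the scatter a 1.2-fold lower number from compound 1 to compound 3 (0.08 log units; within the scatter). Compound 2 `COc1cc(C(=O)N2CCC(O)C(C)C2)cc2nc(NCc3cccc(Cl)c3)oc12` gives 25 nM, and its step of a 2.1-fold higher number from compound 1 to compound 2 (0.32 log units; beyond the scatter) is modest. Compound 4 `COc1cc(C(=O)N2CC[C@H](O)[C@@H](C)C2)cc2nc(NCc3cccc(Cl)c3)oc12` differs from compound 3 only in configuration: the two compounds have the same atoms and bonds and differ only in configuration as drawn: 2 of 2 stereo elements differ (all stereocentres are inverted: mirror images); a stereocentre at a saturated ring carbon is drawn R in compound 3 and S in compound 4; a stereocentre at a saturated ring carbon is drawn R in compound 3 and S in compound 4. The step that bears on this change is a 2.5-fold lower number from compound 2 to compound 3 (0.40 log units; beyond the scatter), which rests on (the fact that one of compounds 2 and 3 is drawn with a defined configuration and the other without, at the place where they differ). With compound 2 carrying the same atoms without drawn configuration and standing weaker than compound 3, the mirror image is expected to be weaker than compound 3, beyond the scatter. Compound 4 is expected to give 150 nM, with a range from 40 nM to 600 nM. For compound 4 the expected step is a 15-fold higher number from compound 3 to compound 4 (1.18 log units; beyond the scatter).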

Compound 4, half-maximal inhibitory concentration: 120 nM
Compound 4: middle estimate off by 1.3-fold (0.10 log units), on the high side; the measured number falls inside the stated range.
By their numbers in this assay, from the lowest: compounds 3 and 1 (each within the scatter of the next); then compound 2; then compound 4.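

In this assay, the configuration of the 4-hydroxy-3-methylpiperidin-1-yl amide alone carries a large change, a 12-fold higher number from compound 3 to compound 4 (1.08 log units; beyond the scatter): the fact that compounds 3 and 4 differ only in the configuration as drawn. The form drawn without configuration now lies between the two mirror images, with a 4.8-fold higher number from compound 2 to compound 4 (0.68 log units; beyond the scatter): the fact that one of compounds 2 and 4 is drawn with a defined configuration and the other without, at the place where they differ. Replacing ((oxolan-3-yl)methyl)(propyl)amino therefore gives a 10-fold higher number from compound 1 to compound 4 (1.00 log units; beyond the scatter), whereas compound 3 stays within the scatter of compound 1.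

The compounds shown leave open whether the hydroxy-bearing or the methyl-bearing stereocentre accounts for the step, as both are inverted together. Going by these compounds, how a piperidine with an amine in place of the hydroxy group would stand also remains open.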